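The source may hold more compounds than are shown below. What is called first, only, known or untested is meant among the compounds shown, and "the series" means these compounds.

Compound 1 `O=S(=O)(c1cccc(-c2ccc3ncnc(Nc4ccc(OCc5cccc(F)c5)c(Cl)c4)c3c2)c1)N1CCCC1`, compound 2 `CC(C)(C)NS(=O)(=O)c1ccccc1-c1ccc2ncnc(Nc3ccc(OCc4cccc(F)c4)c(Cl)c3)c2c1` and compound 3 `O=S(=O)(c1ccc(-c2ccc3ncnc(Nc4ccc(O)c(Cl)c4)c3c2)cc1)N1CCOCC1` share one core. In an ADME assay on HepG2 cells (Homo sapiens) for cytotoxicity, read by MTT assay, with a stated time of 48 h (a higher number here means a weaker inhibitor, a lower number a stronger inhibitor), compound 1 reaches only the limit of the assay, > 15000 nM. Compound 3 likewise gives only a limit in this assay, > 15000 nM. For compound 2 this assay shows "not determined" (no result reported). Compound 3 therefore stands at the limit where two of the three values sit (the limit of > 15000 nM in this assay, at which 2 of the 3 values shown sit). Compound 4 `O=S(=O)(c1ccc(-c2ccc3ncnc(Nc4ccc(OCc5cc(F)cc(F)c5F)c(Cl)c4)c3c2)cc1)N1CCOCC1` differs from compound 3 by 2,3,5-trifluorobenzyl in place of hydrogen on an oxygen on an aromatic ring, that is, hydroxy to (2,3,5-trifluorobenzyl)oxy. Among the measured compounds shown here, no measured step shows what such a change does. Compound 1, a close relative bearing a fluorobenzyl group, also stops at its limit > 15000 nM. The expected step that the limit leaves unreadable from compound 3 to compound 4 is none beyond the scatter. Compound 4 is thus expected to give about 20000 nM, between 10000 nM and 40000 nM, most likely again only as a limit.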

Compound 4, half-maximal inhibitory concentration: > 3000 nM
Compound 4 was reported as a limit (the forecaster's own chance of this, stated with the estimate: 70%); the middle value lies beyond the limit too.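

In this assay compound 3 and compound 4 both give only limits, and the step from hydroxy to (2,3,5-trifluorobenzyl)oxy cannot be read. The compounds shown leave open at what concentration any of them would reach half-maximal inhibition.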